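The source may report more compounds than this note shows. Statements on the series, on what has been measured and on what is new or still open speak of the compounds shown alone.

Measured compounds:
compound 1 `CC(C)(C)c1ccc(C(=O)N2CCC3(CC2)C(=O)N(CC(=O)N2CCCC(C(N)=O)C2)CN3c2ccccc2)cc1`, in an assay on HEK293 cells for displacement of a labelled ligand from NPC1-like intracellular cholesterol transporter 1 (Homo sapiens) (on this read-out higher numbers stand for weaker inhibition and lower numbers for stronger inhibition), compound 1 gives 16900 nM;
compound 3 `CC1CCCN(C(=O)CN2CN(c3ccccc3)C3(CCN(C(=O)c4ccc(C(C)(C)C)cc4)CC3)C2=O)C1`, in this assay compound 3 gives 12000 nM;
compound 2 `CC(C)(C)OC(=O)NCCCCNC(=O)CN1CN(c2ccccc2)C2(CCN(C(=O)c3ccc(C(C)(C)C)cc3)CC2)C1=O`, for which in this assay compound 2 gives "not determined" (no result reported).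

Within the data shown here, only two numbers are known. Compound 3 and compound 1 sit within the scatter of each other: the step of a 1.4-fold lower number from compound 1 to compound 3 (0.15 log units; within the scatter) is too small to rank them. Both numbers are high, so on this read-out both compounds are weak.

Compound 4 `CC(C)(C)c1ccc(C(=O)N2CCC3(CC2)C(=O)N(CC(=O)NCCCCN)CN3c2ccccc2)cc1` differs from compound 3 at the carbonyl carbon whose other neighbour is a saturated chain carbon:

(4-aminobutyl)amino in place of 3-methylpiperidin-1-yl on a carbonyl carbon

Among the measured compounds shown here, no measured step bears on this change. For the measured compounds named here, the only step in hand, a 1.4-fold lower number from compound 1 to compound 3 (0.15 log units; within the scatter), swaps a group on a saturated ring carbon while the ring itself stays, and it lay within the scatter. Here the ring leaves and an open chain with two hydrogen-bond donors enters, for which there is no precedent among the numbers; compound 2, which carries a related chain, has no result. The expectation is therefore a step of a 1.3-fold higher number from compound 3 to compound 4 (0.10 log units; within the scatter), with wide uncertainty. Compound 4 is estimated at 15000 nM in this assay, between 4000 nM and 60000 nM.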

Compound 4, half-maximal inhibitory concentration: 14500 nM
Compound 4: the middle estimate sits 1.0-fold (0.01 log units) above what was measured; measured number inside the range.
By their numbers in this assay, from the lowest: compounds 3, 4 and 1 (each within the scatter of the next).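

At this carbonyl carbon, the 3-methylpiperidin-1-yl ring can give way to the open (4-aminobutyl)amino chain with no change that stands out from the scatter in this assay (a 1.2-fold higher number from compound 3 to compound 4 (0.08 log units; within the scatter)). The same chain also stays within the scatter when it takes the place of the 3-carbamoylpiperidin-1-yl ring (a 1.2-fold lower number from compound 1 to compound 4 (0.07 log units; within the scatter)). Among these three compounds, then, a ring at this place is not needed to keep the number where it is, although all three numbers remain high, and no measurement at hand explains why the change leaves so little mark.

On these data alone, whether a longer chain, a carboxylic acid in place of the amine, or a piperazine ring at this carbonyl carbon would move the number beyond the scatter stays open. Also open, as far as these compounds go, is whether any group at this place can bring the number much lower.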